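From 3-fluorobenzyl to benzyl on a shared core

This account rests on a few compounds, and the source may have more. Where it says the series, first, only, none or still open, it means among the compounds named here.

Measured in a functional assay on MCF7 cells (Homo sapiens) for inhibition, read by MTT assay (a higher number here means a weaker inhibitor of growth, a lower number a stronger inhibitor of growth), so far
Compound 1 `CC1=C(/C=C/C(C)=C/C=C/C(C)=C\C(=O)NCc2cccc(F)c2)C(C)(C)CCC1n1ccnc1` gives 1810 nM
Compound 2 `CC1=C(/C=C/C(C)=C/C=C/C(C)=C\C(=O)NCc2ccc(O)cc2)C(C)(C)CC=C1c1cncnc1` gives 4960 nM
Compound 3 `CC1=C(/C=C/C(C)=C/C=C/C(C)=C\C(=O)Nc2ccccc2)C(C)(C)CC=C1c1cncnc1` gives 7010 nM

Compound 1 has the lowest number of the three, and the values of compounds 2 and 3 both lie beyond the scatter from it. Compound 4 `CC1=C(/C=C/C(C)=C/C=C/C(C)=C\C(=O)NCc2ccccc2)C(C)(C)CCC1n1ccnc1` has not yet been measured. It keeps the core of compound 1 and differs from it in one place hydrogen in place of fluoro on an aromatic carbon with hydrogen in place of fluoro on an aromatic carbon, so that 3-fluorobenzyl becomes benzyl.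

Among the compounds with values here, only one measured step is available, and it bears on this change only loosely. That step is a 1.4-fold higher number from compound 2 to compound 3 (0.15 log units; within the scatter) and comes with phenyl in place of 4-hydroxybenzyl on an amide-type nitrogen. Within the data shown here, it also stays within the scatter, but compounds 2 and 3 have a different core from compound 1, and no measured step removes a fluoro. The data therefore give no reason to expect a change beyond the scatter in this assay and no direction for one. The expected step is a 1.1-fold higher number from compound 1 to compound 4 (0.04 log units; within the scatter) and leaves the estimate close to compound 1. Compound 4 is estimated at 2000 nM with 1000 nM to 4000 nM as its expected range.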

Compound 4, concentration for 50% growth inhibition: 9770 nM
Estimate against measurement, compound 4: 4.9-fold (0.69 log units) below; the whole stated range lies below it.
By their numbers in this assay, from the lowest: compound 1; then compounds 2, 3 and 4 (each within the scatter of the next).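

In this assay, putting hydrogen in place of fluoro on an aromatic carbon gives a 5.4-fold higher number from compound 1 to compound 4 (0.73 log units; beyond the scatter), which shows that on the core of compound 1 this one atom of the 3-fluorobenzyl group can move the number beyond the scatter. Within the data shown here, the only earlier step, a 1.4-fold higher number from compound 2 to compound 3 (0.15 log units; within the scatter), concerned the group on the amide nitrogen on a different core and stayed within the scatter, so it gave no sign that a change this small in atoms could matter so much. Of this pair, the 3-fluorobenzyl compound is the stronger inhibitor of growth, but nothing at hand accounts for the difference.

The compounds shown leave open whether the fluoro itself is needed, or whether a chloro, methyl or methoxy group on the same aromatic carbon would keep the number near that of compound 1. They also leave open whether the same exchange of fluoro for hydrogen would give a step of similar size on the core of compound 2 and compound 3.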